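The source may hold more compounds than are shown below. What is called first, only, known or untested is meant among the compounds shown, and "the series" means these compounds.

Measured compounds:
- Compound 1, `O=C(C1CC1)[C@H]1C[C@@H]2CNC[C@@H](C2)C1`, in an assay on SHEP1 cells for displacement of a labelled ligand from Neuronal acetylcholine receptor; alpha4/beta2 (Homo sapiens), read by scintillation counting, with a stated time of 2 h (on this read-out lower numbers stand for stronger inhibition and higher numbers for weaker inhibition), compound 1 gives 43 nM
- Compound 2, `O=C(c1ccco1)[C@H]1C[C@@H]2CNC[C@@H](C2)C1`, compound 2 gives 110 nM
- Compound 3, `CNC(=O)[C@H]1C[C@@H]2CNC[C@@H](C2)C1`, compound 3 gives 1.9 nM

Compound 3 stands lowest of the three numbers: the step of a 23-fold lower number from compound 1 to compound 3 (1.35 log units; beyond the scatter) and the step of a 58-fold lower number from compound 2 to compound 3 (1.76 log units; beyond the scatter) are both large and beyond the scatter, while the step of a 2.6-fold higher number from compound 1 to compound 2 (0.41 log units; beyond the scatter) is modest. Compound 4, `CCCNC(=O)[C@H]1C[C@@H]2CNC[C@@H](C2)C1`, differs from compound 3 by ethyl in place of hydrogen on a saturated chain carbon bound to an amide-type nitrogen. Within the data shown here, none of the measured steps changes the amide chain; all three concern what sits on the carbonyl carbon, so they show only that the methylamino group carries the low number of compound 3 and say nothing about lengthening it. The expectation for compound 4 therefore rests on compound 3 alone, with a step of a 2.1-fold higher number from compound 3 to compound 4 (0.32 log units; beyond the scatter) expected to be small or within the scatter, leaning toward a somewhat higher number. Compound 4 is estimated at 4 nM, with a range from 1.2 nM to 15 nM.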

Compound 4, inhibition constant: 6 nM
Compound 4: middle estimate off by 1.5-fold (0.18 log units), on the low side, within the range that was stated.
By their numbers in this assay, from the lowest: compound 3; then compound 4; then compound 1; then compound 2.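

In this assay, the amide chain turns out to be a place where length changes the number: ethyl in place of hydrogen on a saturated chain carbon bound to an amide-type nitrogen gives a 3.2-fold higher number from compound 3 to compound 4 (0.50 log units; beyond the scatter) and so a modest step beyond the scatter. The advantage of an amine-bearing carbonyl group over the carbon groups on that carbonyl carbon nevertheless survives this change, with a 7.2-fold lower number from compound 1 to compound 4 (0.86 log units; beyond the scatter) on replacing cyclopropyl and an 18-fold lower number from compound 2 to compound 4 (1.26 log units; beyond the scatter) on replacing furan-2-yl. Nothing available explains why the longer chain gives the higher number.

With only methylamino and propylamino to compare, two points cannot show whether the number keeps rising as the chain grows, and an ethylamino or butylamino group would test that. As far as these compounds go, how a dimethylamino group, which lacks the amide hydrogen, would read on the same carbonyl carbon also remains open.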